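Adding a methoxy group to compound 1

This account rests on a few compounds, and the source may have more. Where it says the series, first, only, none or still open, it means among the compounds named here.

- compound 1 (`O=C(/C=C/c1csc2ccccc12)c1ccccc1O`): 6200 nM
- compound 2 (`Cc1ccc(O)c(C(=O)/C=C/c2csc3ccccc23)c1`): 4900 nM
- compound 3 (`COc1ccc(C(=O)/C=C/c2csc3ccccc23)c(O)c1`): not yet measured

In a functional assay on KB cells (Homo sapiens) for antiproliferative activity, read by sulforhodamine B assay, with a stated time of 72 h (a lower number here means a stronger inhibitor, a higher number a weaker inhibitor), compound 1 gives 6200 nM. Among the measured compounds shown here, only one other value is available, and it lies within the scatter of this one, so the two cannot be ranked. Compound 3 differs from compound 1 at one place: methoxy in place of hydrogen on an aromatic carbon, meta to a hydroxy group and para to a large group (methoxy in place of hydrogen on an aromatic carbon). For the measured compounds named here, the one measured step that bears on this is the swap of hydrogen for methyl (a 1.3-fold lower number from compound 1 to compound 2 (0.10 log units; within the scatter)). That is a different group, so it is only a loose guide. No step beyond the scatter is therefore expected in this assay. The expected step is a 1.4-fold lower number from compound 1 to compound 3 (0.14 log units; within the scatter) and no more. Compound 3 is estimated at 4500 nM with an expected range of 1500 nM to 12000 nM around it.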

Compound 3, half-maximal inhibitory concentration: 5600 nM
Compound 3: middle estimate off by 1.2-fold (0.09 log units), on the low side, within the range that was stated.
By their numbers in this assay, from the lowest: compounds 2, 3 and 1 (each within the scatter of the next).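

In this assay the methoxy group gives a 1.1-fold lower number from compound 1 to compound 3 (0.04 log units; within the scatter), so compound 1 and compound 3 cannot be told apart. This adds a second kind of substituent to the picture: on this aromatic carbon, meta to a hydroxy group and para to a large group, a methoxy group brings two heavy atoms and one hydrogen-bond acceptor, with no step beyond the scatter. No supporting measurement here explains this result.

Going by these compounds, whether an amine or a carboxylic acid at this carbon, or a longer chain in place of methoxy, would give a step beyond the scatter stays open. On these data alone, all three compounds also carry the hydroxy group, so how the shared core behaves with a methoxy group in its place is unknown.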